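The source may report more compounds than this note shows. Statements on the series, on what has been measured and on what is new or still open speak of the compounds shown alone.

Measured so far in an ADME assay on Vero cells (Chlorocebus sabaeus) for cytotoxicity, read by resazurin assay, with a stated time of 3 days; on this read-out lower numbers stand for stronger inhibition and higher numbers for weaker inhibition:
- compound 1 `CCN(CC)c1cc2[nH]c(C3CCCCC3)nc2cc1NC(=O)c1ccc(N(C)C)cc1`: "not determined" (no result reported)
- compound 2 `CCN(CC)c1cc2[nH]c(C3CCCCC3)nc2cc1NC(=O)OCC(F)(F)F`: the assay limit, > 100 ug/mL
- compound 3 `CN(C)c1cc2[nH]c(C3CCCCC3)nc2cc1NC(=O)OCC(F)(F)F`: the assay limit, > 100 ug/mL

Compound 3 stands at the limit of this assay, so its position relative to compound 2 cannot be read: the step that the two limits leave unreadable from compound 2 to compound 3 has no readable size, since both values sit at the limit of > 100 ug/mL in this assay, at which 2 of the 3 values shown sit. Compound 1 carries no result in this assay.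

Compound 4 `CCCOCC(=O)Nc1cc2nc(C3CCCCC3)[nH]c2cc1N(C)C` differs from compound 3 by propoxymethyl in place of 2,2,2-trifluoroethoxy on a carbonyl carbon. Among the compounds with values here, no measured step touches this part of the molecule, and the one measured step is unreadable, so nothing bears directly on it. With both measured neighbours at the limit, compound 4 is expected to show a step of a number no higher from compound 3 to compound 4 (the limit leaves the size open) within the scatter, and the estimate for compound 4 is 100 ug/mL, ranging from 40 ug/mL to 250 ug/mL.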

Compound 4, half-maximal inhibitory concentration: < 50 ug/mL
Compound 4 gave a limit, no number; the forecaster's own chance of this, stated with the estimate: 65%; middle value at least 2.0-fold (0.30 log units) away from the limit.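

In this assay, propoxymethyl in place of 2,2,2-trifluoroethoxy on a carbonyl carbon gives an at least 2.0-fold lower number from compound 3 to compound 4 (0.30 log units; that floor lies within the scatter). Within the data shown here, this is the first step with a readable floor, and it places a change at this position; the step from compound 2 to compound 3 cannot be read. Compound 4 still carries only a limit, < 50 ug/mL, not a number.

From the compounds shown here alone, how far compound 4 lies from compound 3 remains open, with the floor of the step still within the scatter. Also open, going by these compounds, is whether a propoxy group or a longer chain such as hexyloxymethyl on the same carbonyl carbon would read like compound 4 or compound 3.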